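The compounds below may be only part of what the source reports. "The series", "measured", "known", "first", "only" and "open" are said of these compounds alone.

Measured in an ADME assay on L02 cells (Homo sapiens) for cytotoxicity, read by MTT assay, with a stated time of 24 h; on this read-out higher numbers stand for weaker inhibition and lower numbers for stronger inhibition:
- compound 1 `COc1cc(/C=C2\CN(S(=O)(=O)c3ccc(F)cc3)C/C(=C\c3cc(OC)c(OC)c(OC)c3)C2=O)cc(OC)c1OC`: 12100 nM
- compound 2 `COc1cc(/C=C2\CN(S(=O)(=O)c3ccc(NC(C)=O)cc3)C/C(=C\c3cc(OC)c(OC)c(OC)c3)C2=O)cc(OC)c1OC`: 13600 nM

Compound 1 at 12100 nM and compound 2 at 13600 nM lie within the scatter of each other, so neither stands apart in this assay.

Compound 3 `COc1cc(/C=C2\CN(S(=O)(=O)c3ccc(F)cc3)C/C(=C\c3ccccc3F)C2=O)cc(OC)c1OC` is the next to be read against compound 1: 2-fluorophenyl in place of 3,4,5-trimethoxyphenyl on a double-bonded chain carbon bound to a double-bonded ring carbon. Among the measured compounds shown here, only one measured step is available, a 1.1-fold higher number from compound 1 to compound 2 (0.05 log units; within the scatter), with acetamido in place of fluoro on an aromatic carbon. That step stays within the scatter, but it does not touch the place changed in compound 3. For the measured compounds named here, no measurement yet covers a replacement of 3,4,5-trimethoxyphenyl, and the data give no direction, so no step beyond the scatter is expected in this assay, though with wide uncertainty. The expected step is a 1.1-fold lower number from compound 1 to compound 3 (0.04 log units; within the scatter). For compound 3 the estimated value is 11000 nM, with an expected range of 3500 nM to 35000 nM.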

Compound 3, half-maximal inhibitory concentration: 17600 nM
Compound 3: middle estimate off by 1.6-fold (0.20 log units), on the low side; low and high end bracket the measured number.
By their numbers in this assay, from the lowest: compounds 1, 2 and 3 (each within the scatter of the next).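

In this assay, the change at this double-bonded chain carbon bound to a double-bonded ring carbon, 2-fluorophenyl in place of 3,4,5-trimethoxyphenyl, gives a 1.5-fold higher number from compound 1 to compound 3 (0.16 log units; within the scatter). Among the compounds shown here, the read-out therefore stays within the scatter even though the entering group has fewer heavy atoms and fewer hydrogen-bond acceptors than the group that leaves, and even though this is the first change tried at this position. Nothing available explains this result.

Because fluoro and the methoxy groups differ in the same step, the compounds shown cannot separate the contribution of adding one from that of removing the other. Also open, going by these compounds, is whether this position stays within the scatter with a group of another kind, such as an amine or a carboxylic acid on the phenyl ring.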